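A few compounds are considered here, and "the series" means these few. Any claim that something is new, unique, unknown or untested is made for them only; others in the source may bear on it.

Going by the values given here, the three compounds measured so far share one core and differ only in the fluorine on the sulfonyl-bound phenyl ring. Compound 1 is `O=S(=O)(Nc1ccc(-c2nc3ccccc3o2)cc1)c1cccc(F)c1`. In an assay on isolated protein for inhibition of malate dehydrogenase, mitochondrial (Sus scrofa), with stated times of 45 min and 30 min (a lower number here means a stronger inhibitor, a higher number a weaker inhibitor), compound 1 gives a value that is only a limit, > 63000 nM. Compound 2 is `O=S(=O)(Nc1ccc(-c2nc3ccccc3o2)cc1)c1ccccc1F`. In this assay compound 2 likewise gives only a limit, > 63000 nM. Compound 3 is `O=S(=O)(Nc1ccc(-c2nc3ccccc3o2)cc1)c1ccc(F)cc1`. In this assay compound 3 again gives only a limit, > 63000 nM. The steps among them, a step that the two limits leave unreadable from compound 1 to compound 2, a step that the two limits leave unreadable from compound 1 to compound 3 and a step that the two limits leave unreadable from compound 2 to compound 3, cannot be read in size, because of the limit of > 63000 nM in this assay, at which 3 of the 3 values shown sit. Compound 3 thus stands at the same limit as the other two, with no number to rank it.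

Compound 4 is `COc1ccc(S(=O)(=O)Nc2ccc(-c3nc4ccccc4o3)cc2)cc1`. It differs from compound 3 by methoxy in place of fluoro on an aromatic carbon. Among the compounds with values here, no measured step bears on this change directly, and the fluorine steps show only that moving the fluoro around the ring never lifted any compound above the limit. With no evidence of a gain, the expectation for compound 4 in this assay is a step that the limit leaves unreadable from compound 3 to compound 4, that is, no movement that can be read. Compound 4 is accordingly estimated at 100000 nM, within a range of 40000 nM to 300000 nM, most likely reported again as a limit.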

Compound 4, half-maximal inhibitory concentration: > 63000 nM
Compound 4: only a limit was reported; the forecaster's own chance of this, stated with the estimate: 85%; the middle value is on the limit's open side.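

In this assay compound 4 gives only a limit, > 63000 nM. Its steps from compound 1, compound 2 and compound 3 therefore cannot be read, because all four compounds rest on the same limit: the limit of > 63000 nM in this assay, at which 4 of the 4 values shown sit.

The compounds shown leave open whether any group on the sulfonyl-bound phenyl ring gives a measurable inhibition in this assay.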